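Swapping a Carbamate for a Pyrimidine on a Shared Core

The source may hold more compounds than are shown below. What is called first, only, known or untested is meant among the compounds shown, and "the series" means these compounds.

Within the data shown here, compound 1, `COC(=O)N1c2ccc(C3(NC(=O)c4ccc(F)cc4)CC3)cc2[C@@H]2CC[C@@H]21`, is one of three compounds measured in an assay on HeLa cells for inhibition of Indoleamine 2,3-dioxygenase 1 (Homo sapiens); a lower number here means a stronger inhibitor, a higher number a weaker inhibitor. In this assay compound 1 gives 5.6 nM, the highest of the three numbers. Compound 2, `Cc1nccc(N2CCc3cc(C4(C(=O)Nc5ccc(F)cc5)CCC4)ccc32)n1`, gives 5.2 nM in this assay, and compound 3, `O=C(NC1(c2ccc3c(n2)CCN3C(=O)OC2CC2)CCC1)c1ccc(Cl)cc1`, gives 4.5 nM. Both of these numbers lie within the usual scatter of the value for compound 1, so the three compounds cannot be told apart on potency by these measurements.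

Compound 4, `Cc1nccc(N2c3ccc(C4(NC(=O)c5ccc(F)cc5)CC4)cc3[C@@H]3CC[C@@H]32)n1`, has not yet been measured. It differs from compound 1 in a single place: 2-methylpyrimidin-4-yl in place of methoxycarbonyl on a nitrogen on an aromatic ring in a ring. Among the measured compounds shown here, no pair of measured compounds shows this exchange on its own, so its likely effect has to be judged from what the values show. Compound 2, which also carries 2-methylpyrimidin-4-yl on a nitrogen, sits at 5.2 nM, and compound 1 with its methoxycarbonyl sits at 5.6 nM. Those two numbers are indistinguishable within the scatter.

The step of a 1.1-fold lower number from compound 1 to compound 4 (0.05 log units; within the scatter) is therefore expected to stay within the scatter, with no clear direction. Compound 4 is estimated to give about 5 nM in this assay, with a likely range from 2 nM to 14 nM.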

Compound 4, half-maximal inhibitory concentration: 5 nM
For compound 4 middle estimate and measured number coincide at the digits printed; measured number inside the range.
By their numbers in this assay, from the lowest: compounds 3, 4, 2 and 1 (each within the scatter of the next).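

Among these compounds, the step of a 1.1-fold lower number from compound 1 to compound 4 (0.05 log units; within the scatter) in this assay gives the first direct reading of this exchange. Compound 1 and compound 4 differ only on a nitrogen on an aromatic ring in a ring, with the rest of the shared core unchanged. The entering 2-methylpyrimidin-4-yl brings 7 heavy atoms and a six-membered aromatic ring in place of the 4 heavy atoms and no ring of methoxycarbonyl, yet this step lies within the scatter, so the assay does not separate the two groups at this position on this core. No measurement bears on what lies behind this result.

The compounds shown leave open whether a quite different group on this nitrogen, such as an amine, a carboxylic acid or a longer alkyl chain, would also leave the number within the scatter of compound 1. They also leave open whether the same exchange would behave alike on the cores of compound 2 and compound 3, since neither has a partner here that differs from it in this one place.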